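The source may hold more compounds than are shown below. What is called first, only, known or untested is meant among the compounds shown, and "the series" means these compounds.

Measured compounds:
- compound 1, `COc1ccc(Nc2ccc3cc(NC(=O)c4ccc(OC(C)=O)c(CC=C(C)C)c4)c(=O)oc3c2C)cc1`: > 100000 nM
- compound 2, `COCOc1ccc(Cc2ccc3cc(NC(=O)c4ccc(OC(C)=O)c(CC=C(C)C)c4)c(=O)oc3c2C)cc1OC`: 14900 nM

Going by the values given here, in a functional assay on MCF7 cells (Homo sapiens) for antiproliferative activity (on this read-out lower numbers stand for stronger inhibition and higher numbers for weaker inhibition), compound 2 gives 14900 nM, the only real number in the set. Compound 1 is reported only as a limit of this assay, > 100000 nM. Among the compounds with values here, the value of compound 1 is thus (the limit of > 100000 nM in this assay, at which 1 of the 2 values shown sits), so no measured step exists between the two compounds and nothing shows how large a single change tends to move potency here.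

Compound 3, `COCOc1ccc(Cc2ccc3cc(NC(=O)c4ccc(OC(C)=O)c(CC=C(C)C)c4)c(=O)oc3c2C)cc1`, is to be measured next. It differs from compound 2 by hydrogen in place of methoxy on an aromatic carbon. Within the data shown here, with no measured step to calibrate against, the expectation for compound 3 in this assay is a step of modest size, if any, and more likely toward weaker than stronger inhibition. Compound 3 is estimated at 20000 nM, within 7000 nM to 60000 nM, which means an expected step of a 1.3-fold higher number from compound 2 to compound 3 (0.13 log units; within the scatter).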

Compound 3, half-maximal inhibitory concentration: 22700 nM
Compound 3: middle estimate off by 1.1-fold (0.05 log units), on the low side, within the range that was stated.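

In this assay, the methoxy group ortho to the methoxymethoxy group can be replaced by hydrogen with only a 1.5-fold higher number from compound 2 to compound 3 (0.18 log units; within the scatter), so the two rings, 3-methoxy-4-(methoxymethoxy)phenyl and 4-(methoxymethoxy)phenyl, cannot be told apart on this read-out. Going by these compounds alone, replacing (4-methoxyphenyl)amino with 4-(methoxymethoxy)benzyl gives an at least 4.4-fold lower number from compound 1 to compound 3 (0.64 log units; beyond the scatter), which is the first step beyond the scatter. Compound 1 is held at a limit and not at a number, so this step gives only a minimum size: the limit of > 100000 nM in this assay, at which 1 of the 3 values shown sits.

As far as these compounds go, it remains open whether a 4-methoxybenzyl group would retain the activity of compound 3, which would separate the effect of the amine-to-methylene linker exchange from that of the methoxymethoxy group. From the compounds shown here alone, it is also open whether a hydroxyl or an amine at the position of the methoxy group would move the number beyond the scatter.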